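Swapping the methyl's place on the outer ring

The compounds below may be only part of what the source reports. "The series", "measured", "known", "first", "only" and "open" are said of these compounds alone.

The series shares one core, a phenoxyacetic acid bearing a fluorine, joined through an amide to an aryloxyacetyl arm, and it is tested in a functional assay on CHO cells for agonist activity at Free fatty acid receptor 1 (Homo sapiens), read by FLIPR; on this read-out higher numbers stand for an effect only at larger amounts of compound and lower numbers for an effect already at smaller amounts. Compound 1 `O=C(O)COc1ccc(NC(=O)COc2ccccc2)cc1F` carries an unsubstituted phenoxy arm, and for compound 1 the result stands as "not determined" (no result reported). Compound 2 `Cc1ccccc1OCC(=O)Nc1ccc(OCC(=O)O)c(F)c1` carries a methyl on that outer ring, and for compound 2 the result likewise stands as "not determined" (no result reported). Only compound 3 `Cc1cccc(OCC(=O)Nc2ccc(OCC(=O)O)c(F)c2)c1` has a number: in this assay compound 3 gives 108 nM, so it is the sole reference point in this set.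

Compound 4 `Cc1ccc(OCC(=O)Nc2ccc(OCC(=O)O)c(F)c2)cc1` differs from compound 3 in a single place: 4-methylphenyl in place of 3-methylphenyl on an oxygen on a saturated carbon. The two compounds contain the same atoms, joined differently, so nothing is added or taken away; the methyl simply moves to another spot on the outer ring. Among the measured compounds shown here, no measured pair in this set shows what such a move does, so the direction of the step is open. The change is expected to be small, most likely no larger than the usual scatter, and the step from compound 3 to compound 4 is estimated as a 1.4-fold higher number from compound 3 to compound 4 (0.14 log units; within the scatter). On that basis compound 4 is expected to reach about 150 nM in this assay, with a plausible span from 40 nM to 500 nM.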

Compound 4, half-maximal effective concentration: 148 nM
Estimate against measurement, compound 4: 1.0-fold (0.01 log units) above; the range from low to high includes it.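

In this assay, replacing 3-methylphenyl with 4-methylphenyl on the oxygen-bearing saturated carbon gives a 1.4-fold higher number from compound 3 to compound 4 (0.14 log units; within the scatter) and so leaves the two compounds indistinguishable on this read-out. Among the compounds shown here, this is the first measured pair in the set, and it shows that, for these two isomers, the place of the methyl on the outer ring does not separate compound 3 from compound 4 beyond the normal spread of repeated measurements. Nothing available here accounts for this result or says what the methyl contributes at either place.

On these data alone, the steps linking compound 1 or compound 2 to the other compounds cannot be read, so the effect of the methyl itself, measured against the unsubstituted phenoxy arm, and the effect of the third methyl placing both stay unknown. As far as these compounds go, it also remains open whether this insensitivity would hold for a different group on the outer ring, such as a chlorine, a methoxy or an ethyl, since a methyl is the only substituent on that ring among the compounds with numbers.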